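A few compounds are considered here, and "the series" means these few. Any claim that something is new, unique, unknown or untested is made for them only; others in the source may bear on it.

Working notes on the step from compound 2 to compound 3.

Of the compounds shown here, two have been measured in an ADME assay on Vero cells (Chlorocebus sabaeus) for cytotoxicity; on this read-out higher numbers stand for weaker inhibition and lower numbers for stronger inhibition. Compound 1 `O=C1c2nccnc2C(=O)N1Cc1ccccc1` gives in this assay > 100000 nM, which is a limit of the assay and not a number. Compound 2 `COc1ccc(CN2C(=O)c3nccnc3C2=O)cc1` gives in this assay > 100000 nM, again a limit of the assay rather than a number. The step from compound 1 to compound 2, a methoxy in place of hydrogen on an aromatic carbon, is therefore a step that the two limits leave unreadable from compound 1 to compound 2; both values sit at the limit of > 100000 nM in this assay, at which 2 of the 2 values shown sit, so neither its size nor its direction can be read.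

Compound 3 `COc1ccc(CN2C(=O)c3nccnc3C2=O)cc1OC` has not yet been measured in this assay. It differs from compound 2 by methoxy in place of hydrogen on an aromatic carbon. Within the data shown here, the only measured step that bears on this change is the one from compound 1 to compound 2, and it is unreadable, so no size or direction beyond the scatter can be drawn from it. Since compound 2 itself gives only > 100000 nM, a limit, a report at that limit rather than a number is the more likely outcome again. Compound 3 is expected to give in this assay about 150000 nM, within 60000 nM to 400000 nM, which means an expected step that the limit leaves unreadable from compound 2 to compound 3.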

Compound 3, half-maximal inhibitory concentration: > 100000 nM
Compound 3: only a limit was reported (the forecaster's own chance of this, stated with the estimate: 85%); the middle value is on the limit's open side.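

In this assay compound 3 gives > 100000 nM, a limit of the assay and not a number, so the step from compound 2 to compound 3 cannot be read. All values shown share one limit: the limit of > 100000 nM in this assay, at which 3 of the 3 values shown sit.

The compounds shown leave open whether methoxy in place of hydrogen on an aromatic carbon changes this read-out at all.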